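The source may hold more compounds than are shown below. What is called first, only, known or untested is meant among the compounds shown, and "the series" means these compounds.

Compound 1 `CC(C)(C)Cn1cc2c(Cl)nc(NC(=O)c3ccccc3)nc2n1` gives 30300 nM in an assay on CHO cells for displacement of a labelled ligand from adenosine receptor A3 (Homo sapiens), read by scintillation counting, with a stated time of 3 h; on this read-out lower numbers stand for stronger inhibition and higher numbers for weaker inhibition. In this assay compound 2 `CC(C)(C)Cn1cc2c(Cl)nc(N)nc2n1` gives only a limit, > 60000 nM. The step from compound 1 to compound 2 reads as an at least 1.9-fold higher number from compound 1 to compound 2 (0.29 log units; that floor lies within the scatter); compound 2 therefore stands at the limit of > 60000 nM in this assay, at which 1 of the 2 values shown sits, with no number of its own. Compound 3 `Cn1cc2c(Cl)nc(N)nc2n1` carries hydrogen in place of tert-butyl on a saturated chain carbon bound to an aromatic nitrogen. No measured step touches the chain on the ring nitrogen, so nothing shown bears on this change. For compound 3 the step from compound 2 is expected to be a step that the limit leaves unreadable from compound 2 to compound 3, without a direction beyond the scatter. Compound 3 is estimated at 90000 nM, between 30000 nM and 300000 nM.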

Compound 3, inhibition constant: > 100000 nM
Compound 3: only a limit was reported; the forecaster's own chance of this, stated with the estimate: 75%; at least 1.1-fold (0.04 log units) between middle value and limit.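

Going by these compounds alone, compound 2 and compound 3 each carry only a limit, and no step between them can be read. The compounds shown leave open whether the change from neopentyl to methyl shifts affinity at all.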